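This account rests on a few compounds, and the source may have more. Where it says the series, first, only, none or still open, it means among the compounds named here.

Measured so far:
- compound 1 `O=c1sc2ccccc2n1CCCCCN1CCN(CCCCCn2c(=O)sc3ccccc32)CC1`: 430 nM
- compound 2 `O=c1sc2ccccc2n1CCCCCN1CCN(CCn2c(=O)sc3ccccc32)CC1`: 1710 nM
- compound 3 `O=c1sc2ccccc2n1CCCCN1CCN(CCCn2c(=O)sc3ccccc32)CC1`: 1710 nM

In an assay on SW1353 cells (Homo sapiens) for inhibition, read by a luciferase reporter, with stated times of 30 min and 8 h (a higher number here means a weaker inhibitor, a lower number a stronger inhibitor), compound 3 reads 1710 nM, level with compound 2, and together they give the highest number of the three. Compound 1 reads lower at 430 nM, a gap beyond the scatter.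

Compound 4 `O=c1sc2ccccc2n1CCCCCN1CCN(CCCn2c(=O)sc3ccccc32)CC1` differs from compound 3 by a group of 11 heavy atoms (8 carbon, 1 nitrogen, 1 oxygen, 1 sulfur; one five-membered aromatic ring with 2 hetero atoms, one six-membered aromatic ring of carbon only) in place of a group of 10 heavy atoms (7 carbon, 1 nitrogen, 1 oxygen, 1 sulfur; one five-membered aromatic ring with 2 hetero atoms, one six-membered aromatic ring of carbon only), on a saturated chain carbon, four bonds along the chain from an amine nitrogen in a ring, on a saturated chain carbon, four bonds along the chain from an amine nitrogen in a ring. Going by the values given here, no measured pair isolates such a change. Among the compounds with values here, the only guide is compound 1, the larger molecule, at 430 nM, so a small move toward a lower number is expected, within the scatter. The expected step is a 1.7-fold lower number from compound 3 to compound 4 (0.23 log units; within the scatter). For compound 4 the estimated value is 1000 nM, with an expected range of 450 nM to 2200 nM.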

Compound 4, half-maximal inhibitory concentration: 1460 nM
Estimate against measurement, compound 4: 1.5-fold (0.16 log units) below, and the stated range covers the measured number.
By their numbers in this assay, from the lowest: compound 1; then compounds 4, 2 and 3 (each within the scatter of the next).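

In this assay, the group of 11 heavy atoms in place of the group of 10 heavy atoms gives a 1.2-fold lower number from compound 3 to compound 4 (0.07 log units; within the scatter), and at the place two bonds along the chain from an amine nitrogen in a ring it gives a 1.2-fold lower number from compound 2 to compound 4 (0.07 log units; within the scatter), both within the scatter. By contrast, the group of 10 heavy atoms in place of the group of 12 heavy atoms gives a 3.4-fold higher number from compound 1 to compound 4 (0.53 log units; beyond the scatter), beyond the scatter. Nothing measured here explains these steps. Open, going by these compounds, is whether a longer chain on either side of the amine ring would lower the number further than in compound 1, and whether an ether oxygen within the chain would change it.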